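Ring size at the carbonyl in a farnesyl-cysteine series

The compounds below may be only part of what the source reports. "The series", "measured", "known", "first", "only" and "open" are said of these compounds alone.

Measured compounds and their values in a functional assay on BXPC-3 cells (Homo sapiens) for cytotoxicity, read by fluorescence, with a stated time of 48 h; a higher number here means that more compound is needed for the effect, a lower number that less compound is needed:
compound 1 `CC(C)=CCC/C(C)=C/CC/C(C)=C/CSC[C@H](NC(=O)CCCCCN1CCCC1)C(=O)NC1CCCCC1` gives 12700 nM;
compound 2 `CC(C)=CCC/C(C)=C/CC/C(C)=C/CSC[C@H](NC(=O)CCCCCN1CCCC1)C(=O)NC1CCCC1` gives 6800 nM;
compound 3 `CC(C)=CCC/C(C)=C/CC/C(C)=C/CSC[C@H](NC(=O)CCCCCN1CCN(C)CC1)C(=O)N1CCCC1` gives 3200 nM.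

Compound 3 has the lowest number of the three, beyond the scatter from both compound 2 and compound 1. Among the measured compounds shown here, the one counted step among the measured compounds, a 1.9-fold lower number from compound 1 to compound 2 (0.27 log units; within the scatter), concerns a cyclopentyl in place of a cyclohexyl on an amide-type nitrogen and stays within the scatter.

Compound 4 `CC(C)=CCC/C(C)=C/CC/C(C)=C/CSC[C@H](NC(=O)CCCCCN1CCN(C)CC1)C(=O)N1CCCCC1` has not been measured. It differs from compound 3 in one place: piperidin-1-yl in place of pyrrolidin-1-yl on a carbonyl carbon. This is a ring enlarged by one carbon at the carbonyl, the reverse direction of the ring change seen between compound 1 and compound 2, where a smaller ring brought a number within the scatter. The same reasoning suggests that a larger ring here may give a somewhat higher number, but within the scatter.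

For compound 4 the estimated step is a 1.4-fold higher number from compound 3 to compound 4 (0.15 log units; within the scatter). Compound 4 is thus expected to give about 4500 nM, with a range from 2000 nM to 10000 nM.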

Compound 4, half-maximal effective concentration: 8800 nM
The estimate for compound 4 lay 2.0-fold (0.29 log units) below the measured number; the range from low to high includes it.
By their numbers in this assay, from the lowest: compound 3; then compounds 2, 4 and 1 (each within the scatter of the next).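

In this assay, the ring on the carbonyl carbon matters: piperidin-1-yl in place of pyrrolidin-1-yl gives (a 2.8-fold higher number from compound 3 to compound 4 (0.44 log units; beyond the scatter)), a modest step. The earlier ring change, cyclopentyl in place of cyclohexyl on an amide-type nitrogen, stayed within the scatter (a 1.9-fold lower number from compound 1 to compound 2 (0.27 log units; within the scatter)), so this is the first one-place change among the compounds shown to clear it. Nothing measured here accounts for the step.

The compounds shown leave open how other groups on this carbonyl carbon would read, such as morpholin-4-yl, azetidin-1-yl or an open-chain diethylamino group. They also leave open whether the step from pyrrolidin-1-yl to piperidin-1-yl would hold with a different amine at the end of the chain.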